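This account rests on a few compounds, and the source may have more. Where it says the series, first, only, none or still open, it means among the compounds named here.

Compound 1 `C=C1C(=O)[C@]23C[C@@]1(O)CC[C@H]2c1ccc(O)c(C)c1[C@@H]3Cn1cc(-c2ccccc2)nn1`: 260 nM in a functional assay on SW480 cells (Homo sapiens) for cytotoxicity, read by MTT assay, with a stated time of 4 days; a lower number here means a stronger inhibitor, a higher number a weaker inhibitor. Compound 2 `C=C1C(=O)[C@]23C[C@@]1(O)CC[C@H]2c1ccc(O)c(C)c1[C@@H]3Cn1cc(-c2ccccn2)nn1`: 410 nM in this assay.

Compound 2 stands as the higher of the two numbers; the gap to compound 1, a 1.6-fold higher number from compound 1 to compound 2 (0.20 log units; within the scatter), lies within the scatter. Compound 3 `C=C1C(=O)[C@]23C[C@@]1(O)CC[C@H]2c1ccc(O)c(C)c1[C@@H]3Cn1cc(-c2ccc(F)cc2)nn1` differs from compound 2 in one place: 4-fluorophenyl in place of pyridin-2-yl on an aromatic carbon. Within the data shown here, the only step that bears on this change is the aryl swap from compound 1 to compound 2, which stayed within the scatter, so no step beyond the scatter is expected in this assay. Compound 3 is therefore estimated at 300 nM, range 130 nM to 700 nM, a step of a 1.4-fold lower number from compound 2 to compound 3 (0.14 log units; within the scatter) from compound 2.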

Compound 3, half-maximal inhibitory concentration: 250 nM
For compound 3 the middle estimate is 1.2-fold (0.08 log units) above the measured one; measured number inside the range.
By their numbers in this assay, from the lowest: compounds 3, 1 and 2 (each within the scatter of the next).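

In this assay, 4-fluorophenyl on this aromatic carbon of the five-membered aromatic ring with 3 nitrogen gives a 1.6-fold lower number from compound 2 to compound 3 (0.21 log units; within the scatter) and so adds a third aryl group that stays within the scatter. Fluoro in place of hydrogen on the phenyl group gives a 1.0-fold lower number from compound 1 to compound 3 (0.02 log units; within the scatter) and likewise separates nothing. No measurement at hand speaks to a reason for these small steps.

Still open, from the compounds shown here alone, is whether a carboxylic acid or an amine on the aryl group moves the number beyond the scatter. The same holds for a longer alkyl chain in place of the aryl group.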